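A few compounds are considered here, and "the series" means these few. Any claim that something is new, unique, unknown or untested is made for them only; others in the source may bear on it.

Compound 1 `Cc1cc(=O)n(-c2ccc(F)cc2)nc1C(=O)Nc1ccc(Oc2ncnc3[nH]ccc23)cc1` gives 4800 nM in a functional assay on MCF7 cells (Homo sapiens) for cytotoxicity, read by MTT assay, with a stated time of 72 h; a higher number here means a weaker inhibitor, a lower number a stronger inhibitor. Compound 2 `Cc1cc(=O)n(-c2cccc(F)c2)nc1C(=O)Nc1ccc(Oc2ncnc3[nH]ccc23)cc1` carries 3-fluorophenyl in place of 4-fluorophenyl on an aromatic nitrogen and gives 9670 nM in this assay, so a 2.0-fold higher number from compound 1 to compound 2 (0.30 log units; within the scatter). Compound 3 `Cc1cc(=O)n(-c2ccc(F)cc2)nc1C(=O)Nc1ccc(Oc2ncnc3[nH]ccc23)c(F)c1` carries fluoro in place of hydrogen on an aromatic carbon and gives 24500 nM in this assay, a step of a 5.1-fold higher number from compound 1 to compound 3 (0.71 log units; beyond the scatter), which leaves compound 3 with the highest of the three numbers. Compound 4 `Cc1cc(=O)n(-c2cccc(F)c2)nc1C(=O)Nc1ccc(Oc2ncnc3[nH]ccc23)c(F)c1` has not yet been measured. It differs from compound 3 by 3-fluorophenyl in place of 4-fluorophenyl on an aromatic nitrogen, the same change as from compound 1 to compound 2, and it also carries the fluoro of compound 3. Because a 2.0-fold higher number from compound 1 to compound 2 (0.30 log units; within the scatter) stayed within the scatter, a step of about a 1.8-fold higher number from compound 3 to compound 4 (0.26 log units; within the scatter) is expected in this assay for compound 4. The estimate for compound 4 in this assay is therefore 45000 nM, expected to fall between 20000 nM and 100000 nM.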

Compound 4, half-maximal inhibitory concentration: 32000 nM
Compound 4: middle estimate off by 1.4-fold (0.15 log units), on the high side, within the range that was stated.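

Swapping 4-fluorophenyl for 3-fluorophenyl on the core that carries the extra fluoro gives a 1.3-fold higher number from compound 3 to compound 4 (0.12 log units; within the scatter), and this small step agrees with the same swap on the core of compound 1: the same change on two cores in this assay, a 2.0-fold higher number (0.30 log units; within the scatter) from compound 1 to compound 2 and a 1.3-fold higher number (0.12 log units; within the scatter) from compound 3 to compound 4, 1.5-fold (0.19 log units) apart, within the scatter of two such steps. Adding the fluoro on the aromatic carbon with 3-fluorophenyl in place gives a 3.3-fold higher number from compound 2 to compound 4 (0.52 log units; beyond the scatter), a step that also matches its earlier counterpart: the same change on two cores in this assay, a 5.1-fold higher number (0.71 log units; beyond the scatter) from compound 1 to compound 3 and a 3.3-fold higher number (0.52 log units; beyond the scatter) from compound 2 to compound 4, 1.5-fold (0.19 log units) apart, within the scatter of two such steps. In this assay, each change therefore behaved alike on the two cores shown, but these four compounds cannot show why, or whether this would hold on any other core.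

The compounds shown leave open how a chloro or a methoxy group would behave in place of either fluoro. They also leave open whether an amine on the same aromatic carbon would fit the pattern.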